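Compound 3: from methyl ester to free acid

This account rests on a few compounds, and the source may have more. Where it says the series, first, only, none or still open, it means among the compounds named here.

Measured in an ADME assay on HFF cells (Homo sapiens) for cytotoxicity, with a stated time of 72 h; a higher number here means that more compound is tolerated, a lower number that less compound is tolerated:
Compound 1 `CC(C)(C)c1ccc(C(=O)Nc2cc(Cl)cnc2-c2nnn[nH]2)cc1`: 1200 nM
Compound 2 `COC(=O)c1cnc(Cl)cc1NC(=O)c1ccc(C(C)(C)C)cc1`: > 50000 nM

Compound 2 stands at the limit of > 50000 nM in this assay, at which 1 of the 2 values shown sits. As far as these compounds go, this is a limit of the assay and not a number, so the true position of compound 2 is unknown. Compound 1 gives 1200 nM, and so less of it is tolerated.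

Compound 3 `CC(C)(C)c1ccc(C(=O)Nc2cc(Cl)ncc2C(=O)O)cc1` differs from compound 2 in a single place: hydrogen in place of methyl on an oxygen next to a carbonyl group. It carries hydrogen in place of methyl on an oxygen next to a carbonyl group, which turns methoxycarbonyl into carboxy.

For the measured compounds named here, no measured pair shows this change, so any expectation for this assay remains uncertain. A modest move towards lower tolerance is expected, and compound 3 may well be reported only as a limit too. This expectation starts from compound 2, whose > 50000 nM is a limit. The expected change is an at least 1.6-fold lower number from compound 2 to compound 3 (0.22 log units; that floor lies within the scatter). Compound 3 is estimated at 30000 nM, with an expected range of 6000 nM to 50000 nM.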

Compound 3, half-maximal cytotoxic concentration: 23600 nM
Estimate against measurement, compound 3: 1.3-fold (0.10 log units) above; the range from low to high includes it.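

Compound 3 gives a readable number in this assay, 23600 nM. Compound 2, the methyl ester, offered only a limit. Turning methoxycarbonyl into carboxy gives an at least 2.1-fold lower number from compound 2 to compound 3 (0.32 log units; beyond the scatter), so hydrogen in place of methyl on an oxygen next to a carbonyl group does change the result, and the free acid is tolerated less than the methyl ester. This step is only a floor and its true size remains unknown, because compound 2 stands at a limit and not at a number: the limit of > 50000 nM in this assay, at which 1 of the 3 values shown sits.

As far as these compounds go, what a primary amide or an ethyl ester would give in this assay remains open, and with it whether the lower number belongs to the carboxy group alone or would follow from other replacements of methoxycarbonyl at this place. A single step also cannot tell whether the same change would have a similar effect on another core, so no general rule for this change can be drawn from the compounds shown.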